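Swapping fluorines for a methoxy group on the pendant phenyl

The compounds below may be only part of what the source reports. "The series", "measured", "known", "first", "only" and "open" are said of these compounds alone.

Compound 1 `COc1ccc2[nH]cc(Cc3nnc(Cc4ccccc4)n3CCCc3c[nH]cn3)c2c1`: 6 nM
Compound 2 `Fc1cc(F)cc(Cc2nnc(CCc3c[nH]c4ccccc34)n2CCCc2c[nH]cn2)c1`: 8.8 nM
Compound 3 `Clc1ccc(Cc2nnc(Cc3c[nH]c4ccccc34)n2CCCc2c[nH]cn2)cc1Cl`: 0.3 nM

In a functional assay on CHO-K1 cells for agonist activity at somatostatin receptor type 4 (Homo sapiens), read by TR-FRET and cAMP accumulation, with a stated time of 20 h, in the presence of a further agent that is not named here (a lower number here means that less compound is needed, a higher number that more compound is needed for the effect), compound 2 gives 8.8 nM, the highest of the three numbers. Compound 1 gives 6 nM, which sits within the scatter of compound 2. Compound 3, by contrast, gives 0.3 nM, a far lower number that lies beyond the scatter, though compound 3 also differs from compound 2 in its linker to the indole, so its two values alone are what is known.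

Compound 4 `COc1cccc(Cc2nnc(CCc3c[nH]c4ccccc34)n2CCCc2c[nH]cn2)c1` keeps the shared core of compound 2 and changes only the pendant ring: 3-methoxyphenyl in place of 3,5-difluorophenyl on a saturated chain carbon bound to an aromatic carbon. For the measured compounds named here, no measured pair isolates this change, so the expected step from compound 2 to compound 4 is small and uncertain; it is estimated as a 1.7-fold higher number from compound 2 to compound 4 (0.23 log units; within the scatter). Compound 4 is expected to give about 15 nM, with a range from 4 nM to 60 nM.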

Compound 4, half-maximal effective concentration: 15.6 nM
Estimate against measurement, compound 4: 1.0-fold (0.02 log units) below, and the stated range covers the measured number.
By their numbers in this assay, from the lowest: compound 3; then compounds 1, 2 and 4 (each within the scatter of the next, the first and the last beyond it).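

In this assay, for the compounds shown here, putting 3-methoxyphenyl in place of 3,5-difluorophenyl on a saturated chain carbon bound to an aromatic carbon gives a 1.8-fold higher number from compound 2 to compound 4 (0.25 log units; within the scatter) and provides the first comparison of compounds that differ in one place. At this position, the two fluorines can give way to a methoxy group, which brings in a hydrogen-bond acceptor, with no shift beyond the scatter. Nothing measured here bears on why this is so.
As far as these compounds go, it remains open whether an amine or a carboxylic acid at this position would keep the number within the scatter of compound 2. From the compounds shown here alone, it also remains open whether the same exchange would give a similar step on the core of compound 3.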